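The source may report more compounds than this note shows. Statements on the series, on what has been measured and on what is new or still open speak of the compounds shown alone.

Measured compounds:
- compound 1, `CCC[C@@H](OC(C)=O)C1=C(Br)/C(=C/Br)OC1=O`: 1 ug/mL
- compound 2, `CCC[C@@H](OC(C)=O)C1=C(Br)C(=C(Br)Br)OC1=O`: 3.5 ug/mL
- compound 3, `CCC[C@@H](OC(C)=O)C1=C(Br)[C@@](C)(OC)OC1=O`: 2.8 ug/mL

All three share the same brominated lactone core and were tested in a functional assay on KB cells (Homo sapiens) for cytotoxicity; on this read-out lower numbers stand for an effect already at smaller amounts and higher numbers for an effect only at larger amounts of compound. Compound 1 gives the lowest of the three numbers, at 1 ug/mL. Compound 3 stands with the second highest number, 2.8 ug/mL; its nearest neighbour is compound 2, whose 3.5 ug/mL lies within the scatter of that of compound 3, so the two cannot be told apart. The gap from compound 1 to compound 3 is beyond the scatter, so compound 3 reads as the less potent of that pair.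

Compound 4, `CCC[C@@H](OC(C)=O)C1=C(Br)[C@@](CI)(OC)OC1=O`, is the next compound in line and has not yet been measured in this assay. It differs from compound 3 in one place: iodo in place of hydrogen on a saturated chain carbon bound to a saturated ring carbon. Going by the values given here, no measured pair in this set carries the same change, so there is no direct precedent for its effect. Among the compounds with values here, with only three compounds, all within a narrow band, the expectation for compound 4 is a step of a 1.1-fold lower number from compound 3 to compound 4 (0.05 log units; within the scatter) that stays within the usual scatter, with no clear direction. Compound 4 is therefore estimated at 2.5 ug/mL, in the range 1 ug/mL to 6 ug/mL.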

Compound 4, concentration for half-maximal effect: 7.1 ug/mL
Beside the measured number, compound 4's estimate is 2.8-fold (0.45 log units) below it; measured number outside the range, above it.
By their numbers in this assay, from the lowest: compound 1; then compounds 3 and 2 (each within the scatter of the next); then compound 4.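

In this assay, going by these compounds alone, the change from methyl to iodomethyl gives a 2.5-fold higher number from compound 3 to compound 4 (0.40 log units; beyond the scatter) and is the only step in this set that can be read across a single place. Within the data shown here, it shows that the saturated chain carbon bound to a saturated ring carbon does not tolerate every change without effect: a single iodine atom there moves the number upward, to an effect only at larger amounts of compound, which the earlier compounds could not show. Nothing available explains this shift.

From the compounds shown here alone, whether the step belongs to iodo in particular stays open, since one change at this place cannot separate iodo from other groups. Chloro, a hydroxyl or an amine in place of the same hydrogen could show whether the number rises with each of them or with iodo alone.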